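The source may hold more compounds than are shown below. What is called first, only, known or untested is meant among the compounds shown, and "the series" means these compounds.

Of the compounds shown here, three built on a shared core have so far been tested in a functional assay on K562 cells (Homo sapiens) for antiproliferative activity, read by MTT assay, with a stated time of 24 h; a higher number here means a weaker inhibitor, a lower number a stronger inhibitor. Compound 1 `COc1ccc(C(=O)/C=C/c2ccc(-c3ccccc3)cc2)c2c1C=CC(C)(C)O2` reads > 10000 nM, which is a limit of the assay and not a number. Compound 3 `COc1ccc(C(=O)/C=C/c2ccc(OC)c(OC)c2OC)c2c1C=CC(C)(C)O2` reads > 10000 nM, which is likewise a limit. Going by the values given here, compound 2 `COc1ccc(C(=O)/C=C/c2cccc([N+](=O)[O-])c2)c2c1C=CC(C)(C)O2`, carrying a 3-nitrophenyl group, gives 5870 nM, the only true number in the set.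

The next compound is compound 4 `COc1ccc(C(=O)/C=C/c2cccc(Cl)c2)c2c1C=CC(C)(C)O2`, which has not yet been measured. It departs from compound 2 in one place, with chloro in place of nitro on an aromatic carbon, meta to a large group, turning 3-nitrophenyl into 3-chlorophenyl (chloro in place of nitro on an aromatic carbon). Among the compounds with values here, no measured pair in this small set differs in a single place, so this assay offers no direct precedent for this exchange. Within the data shown here, the only anchor is compound 2 at 5870 nM, and no shift beyond the scatter is expected in either direction. Compound 4 could also end at a limit of the assay, as compounds 1 and 3 did. The estimated change is a 1.0-fold higher number from compound 2 to compound 4 (0.01 log units; within the scatter). For compound 4 the expected value is 6000 nM, with an estimated range from 2500 nM to 10000 nM.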

Compound 4, half-maximal inhibitory concentration: > 10000 nM
Compound 4 was reported as a limit; the forecaster's own chance of this, stated with the estimate: 35%; middle value at least 1.6-fold (0.22 log units) from the limit.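

In this assay, going by these compounds alone, the exchange of 3-nitrophenyl for 3-chlorophenyl gives the first step at this place, an aromatic carbon meta to a large group, and it reads an at least 1.7-fold higher number from compound 2 to compound 4 (0.23 log units; that floor lies within the scatter). Compound 4 gives > 10000 nM, which is a limit of the assay and not a number, so compound 2 remains the only compound shown with a true number, and chloro in place of nitro did not yield a second one. Only a floor can be stated for this step, and its true size stays unknown, because the reading for compound 4 is a limit: the limit of > 10000 nM in this assay, at which 3 of the 4 values shown sit.

The compounds shown leave open whether another group in place of the nitro, such as a nitrile, an amine or a carboxylic acid, would give a true number in this assay. Within the data shown here, they also leave open how far compound 4 really lies from compound 2, and compounds 1 and 3 add no step to settle this, as neither differs from compound 2 or compound 4 in one place only.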